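Working notes: tert-butyl to isopropyl on the shared core

The source may hold more compounds than are shown below. What is called first, only, known or untested is meant among the compounds shown, and "the series" means these compounds.

compound 1 `CC(C)Nc1nc2cc(-c3ccc(Cl)cc3)sc2c(=O)[nH]1`: > 15600 nM (a limit)
compound 2 `CC(C)(C)Nc1nc2ccsc2c(=O)[nH]1`: 8400 nM

Among the compounds with values here, in an ADME assay on HepG2 cells (Homo sapiens) for cytotoxicity, read by MTT assay, with a stated time of 72 h (a higher number here means that more compound is tolerated, a lower number that less compound is tolerated), compound 2 gives 8400 nM, the only actual number so far. The value for compound 1 is a limit of the assay. Compound 3 `CC(C)Nc1nc2ccsc2c(=O)[nH]1` differs from compound 2 by hydrogen in place of methyl on a saturated chain carbon bound to a nitrogen on an aromatic ring and two saturated chain carbons, which turns tert-butyl into isopropyl (hydrogen in place of methyl on a saturated chain carbon bound to a nitrogen on an aromatic ring and two saturated chain carbons). Within the data shown here, no measured pair isolates this change, so the expectation starts from compound 2 at 8400 nM. A small rise in tolerated concentration, scarcely beyond the scatter in this assay, is expected, and the estimated change is a 1.3-fold higher number from compound 2 to compound 3 (0.12 log units; within the scatter). For compound 3 the estimate is 11000 nM, with an expected range of 5000 nM to 25000 nM.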

Compound 3, half-maximal cytotoxic concentration: 23900 nM
Estimate against measurement, compound 3: 2.2-fold (0.34 log units) below; low and high end bracket the measured number.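

In this assay, within the data shown here, the tert-butyl to isopropyl change gives the first readable step at this position: a 2.8-fold higher number from compound 2 to compound 3 (0.45 log units; beyond the scatter). A single methyl on the saturated chain carbon therefore separates two measured values on the shared core. Compound 1 stands at a limit, so its step to compound 3, hydrogen in place of 4-chlorophenyl on an aromatic carbon, cannot be read: the limit of > 15600 nM in this assay, at which 1 of the 3 values shown sits.

As far as these compounds go, whether the trend continues to an ethyl or cyclopropyl group on that nitrogen stays open. So does whether the same change gives a similar step on a core carrying 4-chlorophenyl.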